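The compounds below may be only part of what the source reports. "The series", "measured", "known", "first", "only" and "open" are said of these compounds alone.

For the measured compounds named here, compound 1 `CN1CCN(c2nc(Cl)nc3c2ncn3Cc2ccc(C(=O)Nc3ccccc3N)cc2)CC1` is the stronger of the two compounds measured so far. In a functional assay on HCT-116 cells (Homo sapiens) for antiproliferative activity, read by CCK-8 assay, with a stated time of 72 h, tested at 2 uM (a lower number here means a weaker effect, a higher number a stronger effect of the compound at the concentration tested), compound 1 gives 71.6%, the highest of the two numbers in hand. Going by the values given here, the other measured compound, compound 2 `CCCn1cnc2c(NCc3ccc(C(=O)Nc4ccccc4N)cc3)nc(Cl)nc21`, differs from compound 1 in more than one place, so no single step links them; in this assay compound 2 gives 28.5%, a number well below that of compound 1 and beyond the usual scatter.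

The step of interest leads from compound 1 to compound 3 `Nc1ccccc1NC(=O)c1ccc(Cn2cnc3c(Nc4cccc(Cl)c4)nc(Cl)nc32)cc1`, which is not yet measured in this assay. The change is (3-chlorophenyl)amino in place of 4-methylpiperazin-1-yl on an aromatic carbon. Among the compounds with values here, no step between two measured compounds matches this change, so nothing in hand shows its effect directly.

With only compound 1 and compound 2 to go by, the size of the step can only be guessed. A modest fall is expected, roughly at the edge of the scatter, giving an expected step of a number 16.6 percentage points lower from compound 1 to compound 3 (beyond the scatter). Compound 3 is therefore estimated to show 55% in this assay, with a range from 25% to 85%.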

Compound 3, a percentage reported as inhibition, at one concentration (the size of the read-out at that concentration, not a potency): 56.2%
Compound 3: the middle estimate sits 1.2 percentage points below what was measured; measured number inside the range.
By their numbers in this assay, from the lowest: compound 2; then compound 3; then compound 1.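

In this assay, for the compounds shown here, the aromatic carbon next to the ring nitrogen accepts (3-chlorophenyl)amino in place of 4-methylpiperazin-1-yl with a step of a number 15.4 percentage points lower from compound 1 to compound 3 (beyond the scatter), the first change at this position that can be read on its own. The step shows that the six-membered non-aromatic ring with 2 hetero atoms is not needed for a marked effect at the concentration tested: compound 3, which carries a six-membered aromatic ring of carbon only and a hydrogen-bond donor there, still gives 56.2%, although the loss from compound 1 lies beyond the scatter. Nothing measured accounts for this loss, so its cause remains unknown.

A single step cannot show whether the fall follows from the loss of the 4-methylpiperazin-1-yl group, from the aromatic ring that enters or from its chlorine; phenylamino without the chlorine, morpholin-4-yl and piperazin-1-yl without the methyl group at the same carbon would help to separate these parts. As far as these compounds go, it also remains open whether the chlorine would give a different result elsewhere on the entering ring, as in (4-chlorophenyl)amino.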